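The compounds below may be only part of what the source reports. "The series", "measured", "known", "first", "only" and "open" are said of these compounds alone.

Working notes on the series. Compound 3 `C=C1C[C@]23C[C@@]1(O)CC[C@H]2c1ccc(O)c(C)c1[C@@H]3Cn1cc(-c2ccc(OC)cc2)nn1` in a functional assay on HL-60 cells (Homo sapiens) for cytotoxicity, read by MTT assay, with a stated time of 4 days (a higher number here means a weaker inhibitor, a lower number a stronger inhibitor), gives > 20000 nM, which is a limit of the assay and not a number. Compound 3 therefore stands at the limit of > 20000 nM in this assay, at which 2 of the 3 values shown sit, the upper edge of the numbers shown. Among the measured compounds shown here, compound 2 `C=C1C[C@]23C[C@@]1(O)CC[C@H]2c1ccc(O)c(C)c1[C@@H]3Cn1cc(-c2ccc(C(F)(F)F)cc2)nn1` gives 8950 nM in this assay, the one value within range. Compound 1 `C=C1C[C@]23C[C@@]1(O)CC[C@H]2c1ccc(OS(=O)(=O)c2ccc(C)cc2)c(C)c1[C@@H]3Cn1cc(-c2ccc(Cl)cc2)nn1` gives > 20000 nM in this assay, again a limit. Compound 4 `C=C1C[C@]23C[C@@]1(O)CC[C@H]2c1ccc(O)c(C)c1[C@@H]3Cn1cc(-c2ccc(Cl)cc2)nn1` differs from compound 3 by chloro in place of methoxy on an aromatic carbon. For the measured compounds named here, the only measured step that bears on it is an at least 2.2-fold higher number from compound 2 to compound 3 (0.34 log units; beyond the scatter), and the present change removes the methoxy again, so a modest recovery is expected for compound 4, an at least 1.4-fold lower number from compound 3 to compound 4 (0.15 log units; that floor lies within the scatter), though a limit remains possible. Compound 4 is estimated at 14000 nM (range 5000 nM to 40000 nM).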

Compound 4, half-maximal inhibitory concentration: > 20000 nM
Compound 4 was reported as a limit; the forecaster's own chance of this, stated with the estimate: 45%; middle value at least 1.4-fold (0.15 log units) away from the limit.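

In this assay, chloro in place of trifluoromethyl at this position gives an at least 2.2-fold higher number from compound 2 to compound 4 (0.34 log units; beyond the scatter), so a second replacement, after methoxy in an at least 2.2-fold higher number from compound 2 to compound 3 (0.34 log units; beyond the scatter), also falls short of the trifluoromethyl group. Compound 4 gives > 20000 nM, which is a limit of the assay. The steps to compound 4 from compound 3 and from compound 1 cannot be read, and the series now gathers at one edge: the limit of > 20000 nM in this assay, at which 3 of the 4 values shown sit.

Still open, on these data alone, is whether an amine or a carboxylic acid in the same place on the phenyl ring would give a value within range. As far as these compounds go, how far compound 3 and compound 4 lie from each other also remains unknown.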